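Aryl sulfone series: para-substituent swap on the iodo/methoxy ring

The source may hold more compounds than are shown below. What is called first, only, known or untested is meant among the compounds shown, and "the series" means these compounds.

In an assay on isolated protein for antagonist activity at Rap guanine nucleotide exchange factor 4 (Homo sapiens), read by fluorescence and cAMP accumulation (a lower number here means a stronger inhibitor, a higher number a weaker inhibitor), compound 1 `Cc1cc(C)c(S(=O)(=O)c2ccc(I)cc2)c(C)c1` gives 4000 nM and compound 2 `COc1ccc(S(=O)(=O)c2c(C)cc(C)cc2C)cc1` gives 1900 nM; the step of a 2.1-fold lower number from compound 1 to compound 2 (0.32 log units; beyond the scatter) is the only one measured so far, and compound 2 thus holds the lowest of the two numbers. Compound 3 `Cc1cc(C)c(S(=O)(=O)c2ccc(-c3ccc(F)nc3)cc2)c(C)c1` carries the change 6-fluoropyridin-3-yl in place of methoxy on an aromatic carbon at the same place as that step. Among the compounds with values here, only that one modest step bears on it, and it concerns a different group, so a step of similar modest size, in either direction, is expected: a 1.3-fold lower number from compound 2 to compound 3 (0.10 log units; within the scatter). Compound 3 is therefore estimated at 1500 nM, within 500 nM to 5000 nM.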

Compound 3, half-maximal inhibitory concentration: > 300000 nM
Compound 3 was reported as a limit; the forecaster's own chance of this, stated with the estimate: 10%; middle value at least 200-fold (2.30 log units) away from the limit.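

In this assay this place, para to a large group, is far from indifferent to its substituent: 6-fluoropyridin-3-yl gives an at least 150-fold higher number from compound 2 to compound 3 (2.19 log units; beyond the scatter) and an at least 75-fold higher number from compound 1 to compound 3 (1.87 log units; beyond the scatter), well past the modest 2.1-fold lower number from compound 1 to compound 2 (0.32 log units; beyond the scatter). The value of compound 3 is a limit of the assay, not a number: the limit of > 300000 nM in this assay, at which 1 of the 3 values shown sits. From the compounds shown here alone, the size of the loss at this place therefore remains unknown.

Compound 3 alone carries a ring here, and the contributions of the ring, its nitrogen and its fluorine cannot be separated. Going by these compounds, whether an unsubstituted phenyl, an amine or a carboxylic acid at this place would hold the level of compound 2 remains open.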